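The source may report more compounds than this note shows. Statements on the series, on what has been measured and on what is new or still open speak of the compounds shown alone.

In a functional assay on BT-483 cells (Homo sapiens) for cytotoxicity, read by MTT assay, with a stated time of 24 h (on this read-out lower numbers stand for stronger inhibition and higher numbers for weaker inhibition), compound 1 `CCNc1cc(-c2ccc(NC(=O)Nc3ccc(C(F)(F)F)cc3)cc2C)ccn1` gives 19700 nM. Compound 2 `CCNc1cc(-c2ccc(NC(=O)Nc3ccccc3Cl)cc2C)ccn1` gives > 30000 nM, which is a limit of the assay and not a number. Its standing on the numbers is thus only (the limit of > 30000 nM in this assay, at which 1 of the 2 values shown sits). For the measured compounds named here, the one measured step, with 2-chlorophenyl in place of 4-(trifluoromethyl)phenyl on an amide-type nitrogen, is an at least 1.5-fold higher number from compound 1 to compound 2 (0.18 log units; that floor lies within the scatter).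

Compound 3 `CCNc1cc(-c2ccc(NC(=O)Nc3ccccc3Cl)cc2C(F)(F)F)ccn1` carries a change at another place, with trifluoromethyl in place of methyl on an aromatic carbon, ortho to a 2-(ethylamino)pyridin-4-yl group and meta to a large group: trifluoromethyl in place of methyl on an aromatic carbon. The measured step does not touch this carbon, so it bears on the change only indirectly and gives no size or direction for it. What it does show is that the series sits near the top of the measurable range in this assay. No step beyond the scatter is therefore expected, and a further limit would be no surprise. The expected change is a number no higher from compound 2 to compound 3 (the limit leaves the size open). For compound 3 the estimated value is 30000 nM, with an expected range from 14000 nM to 60000 nM.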

Compound 3, half-maximal inhibitory concentration: 20800 nM
Estimate against measurement, compound 3: 1.4-fold (0.16 log units) above, within the range that was stated.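

Trifluoromethyl in place of methyl on this aromatic carbon, ortho to a 2-(ethylamino)pyridin-4-yl group, gives an at least 1.4-fold lower number from compound 2 to compound 3 (0.15 log units; that floor lies within the scatter). With the larger group on this carbon, compound 3 stays within the measurable range of this assay at 20800 nM, so this position accepts trifluoromethyl and the read-out remains a measured number. The floor of the step does not establish a real change, and its true size stays unread because the entry for compound 2 is a limit of the assay and not a number: the limit of > 30000 nM in this assay, at which 1 of the 3 values shown sits.

On these data alone, the change is seen here only with the 2-chlorophenyl group on the amide-type nitrogen, so it remains open whether it would hold with the 4-(trifluoromethyl)phenyl group of compound 1, whose own step also rests on a limit. As far as these compounds go, it also remains open how a plain hydrogen, a chlorine, a methoxy group or an amine on this carbon would compare with methyl and trifluoromethyl.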